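The source may report more compounds than this note shows. Statements on the series, on what has been measured and on what is new or still open speak of the compounds shown alone.

Three compounds share one core and differ in a single group on it. Compound 1 `Nc1cc(N)c2nc(-c3ccccc3)c(Oc3ccc(Cl)c(Cl)c3)nc2c1` carries a 3,4-dichlorophenoxy group, and in a functional assay on SF-295 cells (Homo sapiens) for inhibition, read by sulforhodamine B assay, with a stated time of 48 h (on this read-out lower numbers stand for higher toxicity in this test and higher numbers for lower toxicity in this test), compound 1 gives 69200 nM. Compound 2 `Nc1cc(N)c2nc(-c3ccccc3)c(NCc3ccc(F)cc3)nc2c1` carries a (4-fluorobenzyl)amino group instead, and in this assay compound 2 gives 64600 nM. The step of a 1.1-fold lower number from compound 1 to compound 2 (0.03 log units; within the scatter) shows these two values as indistinguishable. Compound 3 `Nc1cc(N)c2nc(-c3ccccc3)c(Sc3ccc(Cl)c(Cl)c3)nc2c1` carries a (3,4-dichlorophenyl)sulfanyl group. For compound 3 the result in this assay is only a limit, < 100000 nM, as recorded in the limit of < 100000 nM in this assay, at which 1 of the 3 values shown sits. Because of that limit the steps a step that the limit leaves unreadable from compound 1 to compound 3 and a step that the limit leaves unreadable from compound 2 to compound 3 cannot be read in size, so compound 3 stands merely as a compound whose number lies somewhere under the edge of the assay, with no firm position relative to compound 1 or compound 2.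

Compound 4 `Nc1cc(N)c2nc(-c3ccccc3)c(Oc3ccc(F)cc3)nc2c1` is not yet measured. The change from compound 3 is 4-fluorophenoxy in place of (3,4-dichlorophenyl)sulfanyl on an aromatic carbon. Compound 1 shows that a phenoxy linkage with halogen substitution gives 69200 nM, and compound 2 shows a fluorine-bearing side group giving 64600 nM; both numbers sit close together. For compound 4, therefore, a value of about 65000 nM in this assay is expected, between 30000 nM and 130000 nM, which would mean a step that the limit leaves unreadable from compound 3 to compound 4 whose direction cannot be judged against a limit.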

Compound 4, concentration lethal to 50% of the cells: 72400 nM
Compound 4: the middle estimate sits 1.1-fold (0.05 log units) below what was measured; the range from low to high includes it.
By their numbers in this assay, from the lowest: compounds 2, 1 and 4 (each within the scatter of the next).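

Setting 4-fluorophenyl in place of 3,4-dichlorophenyl on the oxygen gives a 1.0-fold higher number from compound 1 to compound 4 (0.02 log units; within the scatter), so in this assay this exchange of halogen-bearing aromatic rings on the phenoxy linkage leaves the two compounds indistinguishable. Setting 4-fluorophenoxy in place of (4-fluorobenzyl)amino on the same aromatic carbon gives a 1.1-fold higher number from compound 2 to compound 4 (0.05 log units; within the scatter), which again lies within the scatter, so compound 1, compound 2 and compound 4 now form a set of three with no readable difference, and the change of side group at this position has not yet separated any two readable compounds. All steps that involve compound 3 cannot be read in size, and its sulfanyl linkage cannot be compared with the others, because the result for compound 3 is only a limit: the limit of < 100000 nM in this assay, at which 1 of the 4 values shown sits.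

What the compounds shown leave open is whether any group at this position can move the number in this assay beyond the scatter. A carboxylic acid, a morpholine or a longer chain carrying the aromatic ring on this carbon would test that, as would a plain phenoxy group with no halogen.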